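Aryloxypropyl chain end variation on the shared core

This account rests on a few compounds, and the source may have more. Where it says the series, first, only, none or still open, it means among the compounds named here.

Within the data shown here, compound 1 `NC1=NC2(CCOCC2)N(OCCCOc2cccc(Cl)c2)C(N)=N1` is the one member of this set that carries a number in an assay on isolated protein for inhibition of Dihydrofolate reductase (Homo sapiens), read by spectrophotometry, using NADPH, with stated times of 5 s and 6 min, tested at 50 uM; on this read-out lower numbers stand for a weaker effect and higher numbers for a stronger effect at the one concentration tested: compound 1 gives 85.8%. Compound 2 `NC1=NC2(CCOCC2)N(OCCCOc2cc(Cl)c(Cl)cc2Cl)C(N)=N1` was entered in this assay as well, but for compound 2 the entry reads "not determined" (no result reported). Compound 3 `NC1=NC2(CCSCC2)N(OCCCOc2ccc(Br)cc2)C(N)=N1` was entered too, and for compound 3 the entry reads "not determined" (no result reported). So compound 1 stands alone on the numbers and no step between two measured compounds can be read from the data.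

Compound 4 `NC1=NC2(CCOCC2)N(OCCCOc2ccccc2Br)C(N)=N1` has not been measured. Computed from the two structures, it differs from compound 1 in one place: 2-bromophenyl in place of 3-chlorophenyl on an oxygen on a saturated carbon. The shared core, the chain and the ether oxygen stay as in compound 1; only the halogenated ring at the chain end is exchanged, one halogen for another, with the same count of heavy atoms, donors and acceptors on both sides.

Among the measured compounds shown here, with no measured pair to anchor the size of such a change, the direction in this assay rests on compound 1 alone. Because compound 1 sits at 85.8%, near the upper end of the scale, there is little room upward, and a small loss or a step within the scatter is the more likely outcome. Compound 4 is expected to give 78% in this assay, with a range from 55% to 92%. The step this estimate means, a number 7.8 percentage points lower from compound 1 to compound 4 (within the scatter), is expected to stay close to the scatter.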

Compound 4, a percentage reported as inhibition, at one concentration (the size of the read-out at that concentration, not a potency): 85%
Estimate against measurement, compound 4: 7 percentage points below; the measured number falls inside the stated range.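

In this assay, among these compounds, 2-bromophenyl in place of 3-chlorophenyl on an oxygen on a saturated carbon gives a number 0.8 percentage points lower from compound 1 to compound 4 (within the scatter), the first step that can be read, and it shows that this exchange at the chain end leaves no difference that can be told from the scatter. The exchange alters the halogen and its place on the ring together, so a single step cannot separate the two, and a read-out at one concentration gives the size of the effect and not a potency, so any gap in potency between the two compounds remains unseen. No measurement is at hand that would explain why the two chain ends read alike.

The compounds shown cover only halogenated phenyl ends in this assay, so whether the same read-out holds for a pyridine ring, or for a phenyl ring bearing an amine or a carboxylic acid, stays open. Going by these compounds, a longer chain between the shared core and the ether oxygen is equally open.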